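Cyclohexyl for Isopropyl: Little Change Expected in Acid Dissociation

The source may hold more compounds than are shown below. What is called first, only, known or untested is meant among the compounds shown, and "the series" means these compounds.

Three measured compounds share one core and differ only in the group attached to a nitrogen on an aromatic ring. In a physicochemical assay for acid dissociation, compound 1 `CCCCN(C1=NCCN1)c1c(Br)cccc1Br` gives 11. Compound 2 `CC(C)N(C1=NCCN1)c1c(Br)cccc1Br` gives 11.2 in this assay. Compound 3 `C=C(C)CCN(C1=NCCN1)c1c(Br)cccc1Br` gives 10.9 in this assay. Compound 2 holds the highest of the three numbers, but both gaps around it are small: a number 0.20 log units higher from compound 1 to compound 2 (within the scatter), and a number 0.30 log units lower from compound 2 to compound 3 (within the scatter), each within the scatter.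

Compound 4 `Brc1cccc(Br)c1N(C1=NCCN1)C1CCCCC1` has not yet been measured. It differs from compound 2 by cyclohexyl in place of isopropyl on a nitrogen on an aromatic ring. Going by the values given here, the steps that bear on this change are the two that already swapped the group on that same nitrogen, a number 0.20 log units higher from compound 1 to compound 2 (within the scatter) and a number 0.30 log units lower from compound 2 to compound 3 (within the scatter), neither of which moved beyond the scatter. Since butyl, isopropyl and 3-methylbut-3-en-1-yl at this position all gave much the same number, a cyclohexyl there is expected to behave alike, with an estimated step of a number 0.10 log units lower from compound 2 to compound 4 (within the scatter). Compound 4 is therefore estimated at 11.1, within a range from 10.7 to 11.5.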

Compound 4, acid dissociation constant: 11.3
For compound 4 the middle estimate is 0.20 log units below the measured one; measured number inside the range.
By their numbers in this assay, from the lowest: compounds 3, 1, 2 and 4 (each within the scatter of the next, the first and the last beyond it).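

Cyclohexyl puts a ring on this nitrogen for the first time, and in this assay the exchange for isopropyl gives a number 0.10 log units higher from compound 2 to compound 4 (within the scatter), while the exchange for butyl gives a number 0.30 log units higher from compound 1 to compound 4 (within the scatter), so this ring cannot be told apart from either group. Going by these compounds alone, the exchange for 3-methylbut-3-en-1-yl gives a number 0.40 log units higher from compound 3 to compound 4 (beyond the scatter), the first step at this position to pass beyond the scatter, though only modestly. Nothing available here accounts for that step.

Every group shown on this nitrogen is built from carbon and hydrogen alone, so the effect of an amine, a hydroxyl or a carboxylic acid there remains open. Also open, on these data alone, is whether a phenyl ring, or a smaller ring such as cyclopropyl, would stay within this narrow band.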